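The source may hold more compounds than are shown below. What is called first, only, known or untested is meant among the compounds shown, and "the series" means these compounds.

Measured so far:
compound 1, `Cn1ccc(-c2cccc3c2CCC3c2ncc[nH]2)n1`: 19%
compound 2, `CS(=O)(=O)Nc1cccc2c1CCC2c1ncc[nH]1`: 87%
compound 3, `Cc1ccc2c(c1NS(C)(=O)=O)CCC2c1ncc[nH]1`: 83%

Notes on the series. In a functional assay on CHO cells for agonist activity at Alpha-1A adrenergic receptor (Homo sapiens), read by FLIPR and calcium flux (on this read-out higher numbers stand for larger maximal responses and lower numbers for smaller maximal responses), compound 2 gives 87%, the highest of the three numbers, though compound 3 with 83% sits at the same level: a number 4 percentage points lower from compound 2 to compound 3 (within the scatter). Compound 1, at 19%, lies far off: a number 68 percentage points higher from compound 1 to compound 2 (beyond the scatter).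

Compound 4, `c1cc(-c2nccs2)c2c(c1)C(c1ncc[nH]1)CC2`, is not yet measured. Compared with compound 2 it differs in one place: 1,3-thiazol-2-yl in place of methanesulfonamido on an aromatic carbon.

Among the measured compounds shown here, only one measured step bears on this change. From compound 1 to compound 2 a five-membered aromatic ring with two hetero atoms, 1-methyl-1H-pyrazol-3-yl, gave way to methanesulfonamido on an aromatic carbon, and the response rose sharply: a number 68 percentage points higher from compound 1 to compound 2 (beyond the scatter). The step to compound 4 runs the other way, putting a five-membered aromatic ring with two hetero atoms, 1,3-thiazol-2-yl, back in place of methanesulfonamido. The step from compound 2 to compound 3, a number 4 percentage points lower from compound 2 to compound 3 (within the scatter), touches a different group and adds nothing here. A large downward step is therefore expected, a number 57 percentage points lower from compound 2 to compound 4 (beyond the scatter), toward the level of compound 1, with wide uncertainty since 1,3-thiazol-2-yl and 1-methyl-1H-pyrazol-3-yl are not the same ring.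

Compound 4 is estimated at 30%, within 10% to 60%.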

Compound 4, largest response reached (Emax), in percent of the reference or control that the assay uses: 64%
Compound 4: middle estimate off by 34 percentage points, on the low side; measured number above the stated range.
By their numbers in this assay, from the lowest: compound 1; then compound 4; then compounds 3 and 2 (each within the scatter of the next).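

In this assay this aromatic carbon proves able to carry a five-membered aromatic ring with much of the response kept: 1,3-thiazol-2-yl in place of methanesulfonamido gives a number 23 percentage points lower from compound 2 to compound 4 (beyond the scatter) as a modest step. The choice of ring also matters, as 1,3-thiazol-2-yl in place of 1-methyl-1H-pyrazol-3-yl gives a number 45 percentage points higher from compound 1 to compound 4 (beyond the scatter) and the low number of compound 1 therefore does not hold for both rings. No measurement shown here accounts for the difference between these two rings.

From the compounds shown here alone, how a simple amine, a carboxylic acid or a longer chain would stand on this carbon remains open. Also open, going by these compounds, is whether the methyl group of compound 3, which leaves the number within the scatter of compound 2, would do the same alongside 1,3-thiazol-2-yl.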